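The compounds below may be only part of what the source reports. "The series", "measured", "known", "first", "only" and "open" are said of these compounds alone.

Of the compounds shown here, two have so far been measured in a functional assay on QGY-7703 cells (Homo sapiens) for cytotoxicity, read by MTT assay, with a stated time of 24 h; a lower number here means a stronger inhibitor, a higher number a weaker inhibitor. Compound 1 `COc1ccc(/C=C2\CN(C)C/C(=C\c3cccnc3)C2=O)c(OC)c1OC` gives 2630 nM. Within the data shown here, compound 2 `O=C1/C(=C/c2cccnc2)CN(S(=O)(=O)c2ccc(C(F)(F)F)cc2)C/C1=C\c1ccccc1F` gives 4500 nM, and the gap between that number and the one for compound 1 lies within the usual scatter of repeated measurements of this kind, so the two cannot be ranked against each other; compound 2 simply sits alongside compound 1 rather than apart from it.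

Compound 3 `CC(=O)Nc1ccc(S(=O)(=O)N2C/C(=C\c3cccnc3)C(=O)/C(=C/c3ccccc3F)C2)cc1` has not yet been measured in this assay. It differs from compound 2 in one place: acetamido in place of trifluoromethyl on an aromatic carbon. Among the measured compounds shown here, no two measured compounds differ from each other by a single change, so nothing measured so far shows what an exchange of this kind does here. The expectation is therefore that the step of a 1.1-fold lower number from compound 2 to compound 3 (0.05 log units; within the scatter) stays small, with no clear direction beyond the scatter. On that basis compound 3 is estimated at 4000 nM, with a range from 1500 nM to 11000 nM.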

Compound 3, half-maximal inhibitory concentration: 9640 nM
Estimate against measurement, compound 3: 2.4-fold (0.38 log units) below, within the range that was stated.
By their numbers in this assay, from the lowest: compounds 1 and 2 (each within the scatter of the next); then compound 3.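

Among these compounds, this is the first single change that can be read in this assay: acetamido in place of trifluoromethyl, on an aromatic carbon para to a large group, gives a 2.1-fold higher number from compound 2 to compound 3 (0.33 log units; beyond the scatter), a modest step. The position therefore responds to what sits on it, even though the two groups have the same count of heavy atoms, and of this pair trifluoromethyl goes with the lower number. Nothing at hand explains why the number moves.

On these data alone, whether an amine or a methoxy group at this position would stay close to compound 2 or move towards compound 3 remains open. As far as these compounds go, it is also open whether the exchange would shift the number in the same direction on another core: here it is seen only once.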